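A few compounds are considered here, and "the series" means these few. Any claim that something is new, unique, unknown or untested is made for them only; others in the source may bear on it.

Within the data shown here, compound 2 `N#CC1=C(N)OC(c2c[nH]c3ccccc23)=C(C#N)C1c1ccc(F)cc1` is one of two compounds measured in a functional assay, tested at 200 ug/mL (on this read-out higher numbers stand for a stronger effect at the one concentration tested and lower numbers for a weaker effect), where compound 2 gives 22.4%. Among the measured compounds shown here, its only companion is compound 1 `Cc1ccccc1C1C(C#N)=C(N)OC(c2c[nH]c3ccccc23)=C1C#N`, which in this assay gives 21.4%; the gap between the two, a number 1 percentage points higher from compound 1 to compound 2 (within the scatter), lies within the scatter, so the two numbers cannot be told apart.

Compound 3 `N#CC1=C(N)OC(c2c[nH]c3ccccc23)=C(C#N)C1c1cccc2ccccc12` has not yet been measured. The change that leads to it is naphthalen-1-yl in place of 4-fluorophenyl on a saturated ring carbon.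

One earlier step speaks to this change: that from compound 1 to compound 2, where one aromatic group on that same saturated ring carbon was swapped for another, gave a number 1 percentage points higher from compound 1 to compound 2 (within the scatter). Because a number 1 percentage points higher from compound 1 to compound 2 (within the scatter) was within the scatter, the step to compound 3 is expected to be a number 0.4 percentage points lower from compound 2 to compound 3 (within the scatter), with no clear direction. Compound 3 is therefore estimated at 22%, between 10% and 36%.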

Compound 3, a percentage reported as activity, at one concentration (the size of the read-out at that concentration, not a potency): 7.7%
Beside the measured number, compound 3's estimate is 14.3 percentage points above it; measured number outside the range, below it.
By their numbers in this assay, from the lowest: compound 3; then compounds 1 and 2 (each within the scatter of the next).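

In this assay, the swap to naphthalen-1-yl on the saturated ring carbon gives a number 14.7 percentage points lower from compound 2 to compound 3 (beyond the scatter) and, measured against the 2-methylphenyl group, a number 13.7 percentage points lower from compound 1 to compound 3 (beyond the scatter) in the same compound series. The aromatic group at this position therefore can matter, even though the step between 2-methylphenyl and 4-fluorophenyl showed no readable change; the drop goes with two six-membered aromatic rings in place of one, but it rests on compound 3 alone. Nothing measured here gives a reason for the drop.

The compounds shown leave open whether the lower number follows the second ring itself or the way that ring is attached, which naphthalen-2-yl could help to separate. They also leave open how a phenyl ring carrying an amine or a carboxylic acid would read out at this position.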